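This account rests on a few compounds, and the source may have more. Where it says the series, first, only, none or still open, it means among the compounds named here.

In a functional assay on the whole organism (strain albino) for inhibition, with Rattus norvegicus as the target, read by paw edema, with stated times of 30 min and 4 h, at a dose of 0.28 mmol/kg by the oral route (on this read-out higher numbers stand for more inhibition at the one dose given (going by the name of the read-out) and lower numbers for less inhibition), two compounds of this series have been measured so far. Compound 1 `C=CCn1c(SCC(=O)Nc2ccc(/C(C)=N/O)cc2)nnc1-c1ccccc1` gives 73% in this assay. Compound 2 `CCn1c(SCC(=O)Nc2ccc(/C(C)=N/O)cc2)nnc1-c1ccc(OC)cc1` gives 73% in this assay, level with compound 1 at the digits reported; the two values sit within the usual scatter of each other, so no order can be drawn between them. Compound 3 `C=CCn1c(SCC(=O)Nc2ccc(/C(C)=N/O)cc2)nnc1-c1ccc(OC)cc1` has not yet been measured in this assay. It differs from compound 2 in a single place: vinyl in place of methyl on a saturated chain carbon bound to an aromatic nitrogen. Among the measured compounds shown here, no pair of measured compounds shares this one change, so the size of such a step is not known from a measurement. Compound 1 and compound 2 differ in two places and show the same number, which does not tell what either change alone does. The expectation for the step is that it stays within the scatter, neither up nor down, and the estimated step is no change at the digits printed from compound 2 to compound 3 (within the scatter). Compound 3 is accordingly expected to give about 73% in this assay, with a range from 60% to 84%.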

Compound 3, a percentage reported as inhibition, in the whole organism at one dose (the size of the read-out at that dose, not a potency): 75%
For compound 3 the middle estimate is 2 percentage points below the measured one, and the stated range covers the measured number.
By their numbers in this assay, from the lowest: compounds 1, 2 and 3 (each within the scatter of the next).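

In this assay, the change at the saturated chain carbon bound to an aromatic nitrogen, which can also be read as ethyl to allyl, now has a measured size: vinyl in place of methyl gives a number 2 percentage points higher from compound 2 to compound 3 (within the scatter). The same result supplies the other single change on its own, since methoxy in place of hydrogen on an aromatic carbon gives a number 2 percentage points higher from compound 1 to compound 3 (within the scatter), so each of the two changes that separate compound 1 from compound 2 can now be read alone, and neither step leaves the scatter. No evidence is at hand that would explain this result.

What the compounds shown leave open is whether a group of another kind at the chain position, such as a longer chain like hexyl or a chain ending in an amine, would move the number beyond the scatter, and whether a carboxylic acid or a chlorine in place of the methoxy would do so on the aromatic carbon. With a single dose behind every value, they also leave open whether these compounds would stay level at other doses.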